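Moving the pyrazole attachment point on an aryl urea

The source may report more compounds than this note shows. Statements on the series, on what has been measured and on what is new or still open speak of the compounds shown alone.

Measured compounds:
- compound 1, `O=C(NCc1ccncc1)Nc1ccc(S(=O)(=O)c2ccccc2Cl)cc1`: 79 nM
- compound 2, `CCOC(=O)c1ccc(NC(=O)NCc2c[nH]nn2)cc1`: 7750 nM
- compound 3, `CCOC(=O)c1ccc(NC(=O)NCc2cc[nH]n2)cc1`: 69000 nM

All three values come from an assay on isolated protein for activation of Nicotinamide phosphoribosyltransferase (Homo sapiens); on this read-out lower numbers stand for an effect already at smaller amounts and higher numbers for an effect only at larger amounts of compound. Compound 3 stands at the highest number of the three: compound 2 lies closest, and compound 1 furthest away. Within the data shown here, the only measured step that touches the same position is an 8.9-fold higher number from compound 2 to compound 3 (0.95 log units; beyond the scatter), which shows that swapping one small azole for another on that chain carbon can shift the number considerably.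

Compound 4, `CCOC(=O)c1ccc(NC(=O)NCc2cn[nH]c2)cc1`, is not yet measured. Its change from compound 3 is 1H-pyrazol-4-yl in place of 1H-pyrazol-3-yl on a saturated chain carbon bound to an amide-type nitrogen; the two compounds contain the same atoms, joined differently. Among the measured compounds shown here, no measured pair tests exactly this kind of repositioning within one ring, so the direction is open. Given how much the azole swap moved things in this assay, compound 4 is expected to land within a similar spread around compound 3, with a slight lean toward a lower number. The expected step is a 2.3-fold lower number from compound 3 to compound 4 (0.36 log units; beyond the scatter). Compound 4 is therefore estimated at 30000 nM, in a range from 5000 nM to 150000 nM.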

Compound 4, half-maximal effective concentration: 1850 nM
Estimate against measurement, compound 4: 16-fold (1.21 log units) above, and the stated range ends above it.
By their numbers in this assay, from the lowest: compound 1; then compound 4; then compound 2; then compound 3.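

In this assay, moving the attachment point within one pyrazole ring, with no change in atoms, gives a 37-fold lower number from compound 3 to compound 4 (1.57 log units; beyond the scatter), a larger step than the earlier swap of one azole for another. The new compound also changes the picture left by that swap, which had favoured the triazole over the pyrazole: 1H-pyrazol-4-yl gives a 4.2-fold lower number from compound 2 to compound 4 (0.62 log units; beyond the scatter), so the comparison between the two rings depends on where the pyrazole is attached. Nothing available here explains this difference.

As far as these compounds go, it remains open whether 1H-pyrazol-4-yl would give a similar gain on the core of compound 1. Also unresolved is how a 1H-imidazol-4-yl ring, or an ethylene chain in place of the single chain carbon, would compare with compound 4.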